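Shared-core ureas: butyl shortened to ethyl

The compounds below may be only part of what the source reports. "The series", "measured", "known", "first", "only" and "open" are said of these compounds alone.

Compound 1 `CCCCNC(=O)N1CC1C#N` is the reference point here. In a functional assay on L1210 cells (Mus musculus) for inhibition, read by MTT assay (a lower number here means a stronger inhibitor, a higher number a weaker inhibitor), compound 1 gives 12000 nM, the highest of the three numbers in hand. Compound 2 `N#CC1CN1C(=O)Nc1ccc([N+](=O)[O-])cc1` gives 2600 nM in this assay, a lower number that lies beyond the usual scatter. Compound 3 `N#CC1CN1C(=O)NC1CCCCC1` gives 7400 nM in this assay; that number and the number of compound 1 sit within the scatter of each other, so no order between them is read. Within the data shown here, no pair in this set differs in a single place, so no measured step is available to calibrate the change to compound 4.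

Compound 4 `CCNC(=O)N1CC1C#N` differs from compound 1 by hydrogen in place of ethyl on a saturated chain carbon, two bonds along the chain from an amide-type nitrogen; the same difference, cut one bond further out, reads butyl to ethyl. With compound 2 at 2600 nM and compound 3 at 7400 nM giving no single direction against compound 1, the step of a 1.3-fold higher number from compound 1 to compound 4 (0.10 log units; within the scatter) is expected to stay within the scatter, leaning if anything to a higher number. Compound 4 is estimated at 15000 nM, with a range from 6000 nM to 40000 nM.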

Compound 4, half-maximal inhibitory concentration: 14000 nM
Estimate against measurement, compound 4: 1.1-fold (0.03 log units) above; low and high end bracket the measured number.
By their numbers in this assay, from the lowest: compound 2; then compounds 3, 1 and 4 (each within the scatter of the next).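

In this assay, among these compounds, the change from butyl to ethyl gives a 1.2-fold higher number from compound 1 to compound 4 (0.07 log units; within the scatter), the first single-place step. It lies within the scatter, so on this one pair compounds 1 and 4 cannot be ordered, and the chain at this position can be cut back to ethyl with no difference that this read-out resolves. No measured evidence bears on this step, and no cause can be assigned to it.

As far as these compounds go, whether the position stays equally undifferentiated with a longer chain such as octyl, or with an amine or a carboxylic acid at the chain end, remains open. One pair also leaves open whether the same shortening would read alike on any other version of the shared core.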